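Replacing a Difluoromethylfuran Arm with a Pyrazine Arm

This account rests on a few compounds, and the source may have more. Where it says the series, first, only, none or still open, it means among the compounds named here.

Measured compounds:
compound 1, `Nc1nc(-c2ccc(C(F)F)o2)nc2sc(Cc3ccccc3)cc12`, 3000 nM
compound 2, `COc1ccccc1Cc1cc2c(N)nc(-c3ccc(C(F)F)o3)nc2s1`, 516 nM
compound 3, `N#Cc1cccc(-c2nc(N)c3cc(C4(c5ccccc5)CC4)sc3n2)c1`, a limit of > 610 nM

Of the compounds shown here, three sharing a core have been measured in a functional assay on CHO-K1 cells for antagonist activity at adenosine receptor A1 (Homo sapiens), read by a beta-galactosidase reporter and cAMP accumulation, with stated times of 15 min and 6 h; on this read-out higher numbers stand for weaker inhibition and lower numbers for stronger inhibition. Compound 1 gives 3000 nM, the highest of the two plain numbers shown. Compound 2 carries a methoxy in place of hydrogen on an aromatic carbon and gives 516 nM; the change is a 5.8-fold lower number from compound 1 to compound 2 (0.76 log units; beyond the scatter). For compound 3 the assay reports only a limit, (the limit of > 610 nM in this assay, at which 1 of the 3 values shown sits), so no number is known for it.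

The compound still to be measured, compound 4, is `Nc1nc(-c2cnccn2)nc2sc(Cc3ccccc3)cc12`. It differs from compound 1 in one place: pyrazin-2-yl in place of 5-(difluoromethyl)furan-2-yl on an aromatic carbon. Within the data shown here, no measured step concerns this position; the only measured step, a 5.8-fold lower number from compound 1 to compound 2 (0.76 log units; beyond the scatter), changes a different part of the molecule and therefore gives no direct guide. With compound 1 already at the weak end of the shown numbers, the expectation is a step of uncertain direction, most likely within or near the scatter, described as a 1.3-fold higher number from compound 1 to compound 4 (0.12 log units; within the scatter). Compound 4 is thus expected to give about 4000 nM, within a range from 1000 nM to 15000 nM.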

Compound 4, inhibition constant: 91 nM
Compound 4: middle estimate off by 44-fold (1.64 log units), on the high side; the measured number lies below the stated range.
By their numbers in this assay, from the lowest: compound 4; then compound 2; then compound 1.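

Placing pyrazin-2-yl in place of 5-(difluoromethyl)furan-2-yl on the aromatic carbon between two ring nitrogen atoms gives a 33-fold lower number from compound 1 to compound 4 (1.52 log units; beyond the scatter) in this assay and so shows that the group at this position can shift the number strongly, towards stronger inhibition. Among these compounds, the only earlier step, a 5.8-fold lower number from compound 1 to compound 2 (0.76 log units; beyond the scatter) with a methoxy in place of hydrogen elsewhere in the molecule, counts as modest, while this one counts as large, so the first clear sign of a large change comes from this position. The swap alters several things at once, since a five-membered aromatic ring with 1 hetero atom and a difluoromethyl group leaves and a six-membered aromatic ring with 2 hetero atoms enters, and this single step cannot separate those changes.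

The compounds shown leave open which of those changes matters, and a plain furan-2-yl or a pyridin-2-yl at this position, or a methoxy on the benzyl ring of compound 4, would help to separate them. Nothing in the data shown accounts for the size of this step.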